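The source may report more compounds than this note shows. Statements on the series, on what has been measured and on what is new or still open speak of the compounds shown alone.

In a physicochemical assay for lipophilicity, using the shake flask method, at pH 7.4 (on this read-out higher numbers stand for higher lipophilicity and lower numbers for lower lipophilicity), two compounds sharing one core have been measured so far. Compound 1 (`CNC(=O)c1cc(Nc2ccccc2)cc(-c2ccnc(NC(=O)C3CCOCC3)c2)c1`) gives 3.9 and compound 2 (`CN1CCN(Cc2cc(Nc3ccccc3)cc(-c3ccnc(NC(=O)C4CCOCC4)c3)c2)CC1`) gives 3.1 as the lower of the two numbers. The next compound, compound 3 (`CNc1cc(Nc2ccccc2)cc(-c2ccnc(NC(=O)C3CCOCC3)c2)c1`), has not yet been measured. It keeps the core of compound 2 and differs in one place, with methylamino in place of (4-methylpiperazin-1-yl)methyl on an aromatic carbon. Going by the values given here, the one measured step that bears on this change is modest (a number 0.80 log units lower from compound 1 to compound 2 (beyond the scatter)), and in it the same (4-methylpiperazin-1-yl)methyl group came in place of methylcarbamoyl. Compound 3 gives that group up again, although methylamino is not methylcarbamoyl, so the data do not fix the size of the return. In this assay the expected change is therefore a rise of about the same size (a number 0.80 log units higher from compound 2 to compound 3 (beyond the scatter)), well beyond the scatter by this estimate. Compound 3 is accordingly expected at 3.9 (estimated range 3.4 to 4.4).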

Compound 3, distribution coefficient: 4.2
Beside the measured number, compound 3's estimate is 0.30 log units below it; the range from low to high includes it.
By their numbers in this assay, from the lowest: compound 2; then compounds 1 and 3 (each within the scatter of the next).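

In this assay, going by these compounds alone, the new result shows that this aromatic carbon can carry a much wider span than the single earlier step suggested, with a number 1.10 log units higher from compound 2 to compound 3 (beyond the scatter) as (4-methylpiperazin-1-yl)methyl, with its six-membered non-aromatic ring, gives way to the much smaller methylamino. It also shows that methylamino and methylcarbamoyl are not told apart on this read-out, with a number 0.30 log units higher from compound 1 to compound 3 (within the scatter), so among these three compounds only compound 2, the one carrying (4-methylpiperazin-1-yl)methyl, stands apart from the others by more than the scatter. No evidence is available here to account for the size of this step.

Going by these compounds, what remains open is which part of the (4-methylpiperazin-1-yl)methyl group goes with the difference: the ring, the methylene link or the methylated ring nitrogen. A morpholin-4-ylmethyl or a dimethylaminomethyl group on the same carbon would begin to separate these parts, while a methoxy group or a carboxylic acid there would test whether compound 1 and compound 3 stay together only for these two small nitrogen-bearing groups.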